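Thienopyrimidine series: replacing the furan arm with pyridin-2-yl

This account rests on a few compounds, and the source may have more. Where it says the series, first, only, none or still open, it means among the compounds named here.

Measured so far:
- compound 1, `Nc1nc(-c2ccc(C3CC3)o2)nc2sc(Cc3ccccc3)cc12`, 861 nM
- compound 2, `COc1ccccc1Cc1cc2c(N)nc(-c3nc(C)cs3)nc2s1`, 186 nM

In a functional assay on CHO-K1 cells for antagonist activity at adenosine receptor A1 (Homo sapiens), read by a beta-galactosidase reporter and cAMP accumulation, with stated times of 15 min and 6 h (a higher number here means a weaker inhibitor, a lower number a stronger inhibitor), compound 1 gives 861 nM, the highest of the two numbers recorded, so the weaker inhibitor of the pair. Compound 2 sits at 186 nM, a gap beyond the usual scatter, but compound 2 differs from compound 1 in more than one place, so the two values alone do not single out what drives the difference.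

Compound 3, `Nc1nc(-c2ccccn2)nc2sc(Cc3ccccc3)cc12`, is the next member, not yet measured. It differs from compound 1 in one place: pyridin-2-yl in place of 5-cyclopropylfuran-2-yl on an aromatic carbon. For the measured compounds named here, no single-point step has been measured, so the size of this change can only be guessed. The expectation is a modest move to a lower number, a 2.2-fold lower number from compound 1 to compound 3 (0.33 log units; beyond the scatter), on the view that the aryl arm at this position tolerates a smaller heteroaromatic ring. Compound 3 is therefore estimated at 400 nM, within a range of 100 nM to 1500 nM in this assay.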

Compound 3, inhibition constant: 3710 nM
For compound 3 the middle estimate is 9.3-fold (0.97 log units) below the measured one; measured number above the stated range.
By their numbers in this assay, from the lowest: compound 2; then compound 1; then compound 3.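

The position on an aromatic carbon of the shared core is sensitive to the identity of this arm: in this assay, pyridin-2-yl in place of 5-cyclopropylfuran-2-yl gives a 4.3-fold higher number from compound 1 to compound 3 (0.63 log units; beyond the scatter). The hydrogen-bond donor and acceptor counts of the two groups are the same, but the step changes several other things at once: the three-membered carbon ring leaves, a six-membered aromatic ring replaces a five-membered one, the hetero atom changes from oxygen to nitrogen, and the heavy-atom count falls from 8 to 6. No available data bear on the reason for this step.

For the compounds shown here, the single step cannot separate the loss of the cyclopropyl group from the change of ring. Values in this assay for an unsubstituted furan-2-yl and for a pyridin-2-yl carrying a cyclopropyl group would separate these two changes.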